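A few compounds are considered here, and "the series" means these few. Any claim that something is new, unique, unknown or untested is made for them only; others in the source may bear on it.

Measured so far in an ADME assay on L1210/0 cells (Mus musculus) for cytotoxicity, with a stated time of 48 h; a lower number here means a stronger inhibitor, a higher number a weaker inhibitor:
Compound 1 `OC[C@@H]1CCC[C@@H]1Cn1cnc2c(Cl)ncnc21` gives 52500 nM.
Compound 2 `C[C@@]1(CO)O[C@H](c2ccc(N)cc2F)C[C@@H]1O` is reported only as a limit of the assay, > 200000 nM.
Compound 3 `O=c1[nH]c(=O)n([C@H]2C[C@H](O)[C@@H](CO)O2)cc1C#CCO` is likewise reported only as a limit of the assay, > 200000 nM.

Compound 3 therefore stands at the limit of this assay rather than at a number, and it shares that standing with one other value shown (the limit of > 200000 nM in this assay, at which 2 of the 3 values shown sit); compound 1 alone has a measured number, and that number lies far below the limit. Compound 4 `C#COc1cn([C@H]2C[C@H](O)[C@@H](CO)O2)c(=O)[nH]c1=O` differs from compound 3 in one place on the shared core: ethynyloxy in place of 3-hydroxyprop-1-yn-1-yl on an aromatic carbon. Going by the values given here, no step between two measured compounds is available to size such a change, so nothing in the data supports a large shift in either direction. Compound 4 is expected to remain at or near the limit, with an estimate of about 200000 nM and a range from 60000 nM to 500000 nM. The step of a number no higher from compound 3 to compound 4 (the limit leaves the size open) that this estimate means is expected to be none beyond the scatter, and a further limit-only result is the most likely outcome.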

Compound 4, half-maximal inhibitory concentration: > 200000 nM
Compound 4: only a limit was reported (the forecaster's own chance of this, stated with the estimate: 70%); the middle value sits exactly at the limit.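

Compound 3 and compound 4 are both reported only as limits in this assay, so no step between them can be read: the limit of > 200000 nM in this assay, at which 3 of the 4 values shown sit.

The compounds shown leave open whether ethynyloxy in place of 3-hydroxyprop-1-yn-1-yl on the shared core shifts the half-maximal inhibitory concentration at all, in either direction.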